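Methyl for fluoro on the pyridyl sulfonyl ring

The source may report more compounds than this note shows. Statements on the series, on what has been measured and on what is new or still open speak of the compounds shown alone.

The series rests on one shared core, carried by compound 1 `CNCc1cn(S(=O)(=O)c2cncc(Cl)c2)c(-c2cccnc2F)c1F` and compound 2 `CNCc1cn(S(=O)(=O)c2cncc(F)c2)c(-c2cccnc2F)c1F`. Going by the values given here, in a functional assay on the whole organism (strain Jcl:Sprague-Dawley) for inhibition, with Rattus norvegicus as the target, with stated times of 3 min and 3 h, at a dose of 1 mg/kg by the intravenous route (on this read-out lower numbers stand for less inhibition and higher numbers for more inhibition at the one dose given (going by the name of the read-out)), compound 2 gives 99%, which is the only number available, since for compound 1 the read-out is recorded as "not determined" (no result reported). Compound 2 therefore stands alone with its number in this assay, with nothing beside it to mark a trend.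

Compound 3 `CNCc1cn(S(=O)(=O)c2cncc(C)c2)c(-c2cccnc2F)c1F` is not yet measured. It differs from compound 2 by methyl in place of fluoro on an aromatic carbon, a swap of one heavy atom for another at the same place, two atoms from the ring nitrogen. Among the compounds with values here, no measured step of this kind exists here. Given that compound 2 reaches 99%, compound 3 is expected to stay close, with a step of a number 5 percentage points lower from compound 2 to compound 3 (within the scatter) in this assay, most likely within the scatter or slightly lower. The estimate for compound 3 is 94%, ranging from 78% to 100%.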

Compound 3, a percentage reported as inhibition, in the whole organism at one dose (the size of the read-out at that dose, not a potency): 87%
Compound 3: the middle estimate sits 7 percentage points above what was measured; low and high end bracket the measured number.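

Going by these compounds alone, this place on the ring is not indifferent to its substituent: in this assay the change from 5-fluoropyridin-3-yl to 5-methylpyridin-3-yl gives a number 12 percentage points lower from compound 2 to compound 3 (beyond the scatter) and so supplies the first measured step. The step is modest, and at this one dose compound 3 retains most of the inhibition seen for compound 2, so methyl is accepted here, though less well than fluoro. Nothing in the available data accounts for this difference.

As far as these compounds go, whether chloro would sit nearer fluoro or methyl stays open, since compound 1 gives "not determined" (no result reported) in this read-out. Also open, from the compounds shown here alone, are how a methoxy group, a nitrile or an amine would behave at this place, and whether the step between fluoro and methyl would hold at a lower dose.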